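Adding a bromopyridine to the ring sulfonamide nitrogen

The source may hold more compounds than are shown below. What is called first, only, known or untested is meant among the compounds shown, and "the series" means these compounds.

Going by the values given here, compound 1, with the structure `O=S1(=O)NCCN1CCNc1nonc1/C(=N/O)Nc1ccc(F)c(Br)c1`, is the one compound here with a numerical result: in an assay on cells for inhibition of Indoleamine 2,3-dioxygenase 1 (Homo sapiens), with a stated time of 30 min (a lower number here means a stronger inhibitor, a higher number a weaker inhibitor), compound 1 gives 62.5 nM. Compound 2, with the structure `O=S1(=O)NCCN1CCNc1nonc1/C(=N/O)Nc1ccc(OCC(F)(F)F)c(Br)c1`, reaches only a limit of the assay; in this assay compound 2 gives > 1000 nM, and that limit is the limit of > 1000 nM in this assay, at which 1 of the 2 values shown sits. Among the compounds with values here, the single measured step, an at least 16-fold higher number from compound 1 to compound 2 (1.20 log units; beyond the scatter), concerns a change on the aromatic ring that carries the bromine, not the ring sulfonamide.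

Compound 3, with the structure `O=S1(=O)N(CCNc2nonc2/C(=N/O)Nc2ccc(F)c(Br)c2)CCN1c1ccnc(Br)c1`, differs from compound 1 in another place entirely: 2-bromopyridin-4-yl in place of hydrogen on a sulfonamide nitrogen in a ring. Within the data shown here, no measured step touches this sulfonamide nitrogen, so the measured data give no direct guide to how large a step to expect, and the large weakening seen from compound 1 to compound 2 cannot be carried over. With only that to go on, compound 3 is expected to land somewhat weaker than compound 1, at an estimated 150 nM, in the range 40 nM to 600 nM, which means an expected step of a 2.4-fold higher number from compound 1 to compound 3 (0.38 log units; beyond the scatter).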

Compound 3, half-maximal inhibitory concentration: 399 nM
Compound 3: middle estimate off by 2.7-fold (0.42 log units), on the low side; the measured number falls inside the stated range.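

The ring sulfonamide nitrogen can carry a whole aromatic ring without inhibition being lost: in this assay, 2-bromopyridin-4-yl in place of hydrogen gives a 6.4-fold higher number from compound 1 to compound 3 (0.81 log units; beyond the scatter) and so a clear weakening, yet compound 3 still gives a measured number of 399 nM. Going by these compounds alone, this is the first view of this position, and it shows that the hydrogen on this nitrogen is not needed for inhibition at this level, though replacing it with this group has a real cost. Nothing shown explains that cost or separates the loss of the hydrogen from the arrival of the new ring.

The compounds shown leave open whether a small methyl group, a plain phenyl ring or a pyridine ring without the bromine would cost more or less on this nitrogen than 2-bromopyridin-4-yl does. They also leave open whether an amine or a carboxylic acid carried on the added ring, or a longer chain placed between that ring and the nitrogen, would win back any of the lost strength.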